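A few compounds are considered here, and "the series" means these few. Any claim that something is new, unique, unknown or untested is made for them only; others in the source may bear on it.

Working notes on the series.

Compound 1 `Cc1ccc(CS/C(=C/c2ccccc2F)C(=O)c2ccc(Cl)cc2)cc1` and compound 2 `Cc1ccc(CS/C(=C/c2ccc(Br)cc2)C(=O)c2ccc(Cl)cc2)cc1` share one core; compound 3 `O=C(O)c1ccc(C(=O)/C(=C\c2ccccc2F)SCc2ccc(Br)cc2)cc1` carries a second core, and the difference between the two cores is not broken down here. In a functional assay on DU-145 cells (Homo sapiens) for inhibition, read by trypan blue exclusion, with a stated time of 96 h (a higher number here means a weaker inhibitor of growth, a lower number a stronger inhibitor of growth), compound 1 gives 10000 nM, compound 2 gives 10000 nM, and compound 3 gives 10000 nM, so all three stand level at the digits reported. Within the data shown here, the only counted change among the measured compounds is 4-bromophenyl in place of 2-fluorophenyl on a double-bonded chain carbon bound to a double-bonded chain carbon, and this step, no change at the digits printed from compound 1 to compound 2 (within the scatter), stays within the scatter.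

Compound 4 `O=C(O)c1ccc(C(=O)/C(=C\c2ccc(Br)cc2)SCc2ccc(Br)cc2)cc1` has not yet been measured in this assay. Among the measured compounds shown here, it relates to compound 3 by 4-bromophenyl in place of 2-fluorophenyl on a double-bonded chain carbon bound to a double-bonded chain carbon, which is the same change as the one from compound 1 to compound 2, made at the same place on the second core. Because no change at the digits printed from compound 1 to compound 2 (within the scatter) showed no movement on the first core, the expected step for compound 4 is likewise flat, no change at the digits printed from compound 3 to compound 4 (within the scatter), the expectation resting on that single pair and on compound 3 giving 10000 nM. Compound 4 is therefore expected to land at 10000 nM, between 5000 nM and 20000 nM.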

Compound 4, concentration for 50% growth inhibition: 1000 nM
Beside the measured number, compound 4's estimate is 10-fold (1.00 log units) above it; the measured number lies below the stated range.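

In this assay, the replacement of 2-fluorophenyl by 4-bromophenyl does not carry over with the same size from one core to the other, giving a 10-fold lower number from compound 3 to compound 4 (1.00 log units; beyond the scatter), whereas no change at the digits printed from compound 1 to compound 2 (within the scatter), and the two steps differ: the same change on two cores in this assay, no change at the digits printed (within the scatter) from compound 1 to compound 2 and a 10-fold lower number (1.00 log units; beyond the scatter) from compound 3 to compound 4, 10-fold (1.00 log units) apart, beyond the scatter of two such steps

A flat step on the core of compound 1 is therefore no guide to this change on the core of compound 3 in this series. What is not shown is which part of the difference between the two cores goes with the larger step, or why it arises, and the comparison rests on a single pair for each core.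

The compounds shown leave open whether the step on the core of compound 3 follows the halogen or where it sits on the ring, as a 4-fluorophenyl or a 2-bromophenyl at that place would tell. They also leave open whether the step would persist with an amide or an amine in place of the carboxylic acid.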